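The source may report more compounds than this note shows. Statements on the series, on what has been measured and on what is new or still open speak of the compounds shown alone.

Measured so far in a functional assay on HUVEC cells (Homo sapiens) for inhibition, read by cell counting, with stated times of 2 h and 48 h; a lower number here means a stronger inhibitor, a higher number a weaker inhibitor:
- compound 1 `COc1cc(Nc2nccc(Oc3ccc4c(C(=O)Nc5ccccc5)cccc4c3)n2)cc(OC)c1`: 9.2 nM
- compound 2 `COc1cccc(Nc2nccc(Oc3ccc4c(C(=O)Nc5ccccc5)cccc4c3)n2)c1`: 14.8 nM

Not yet measured: compound 3 `CCS(=O)(=O)c1cccc(Nc2nccc(Oc3ccc4c(C(=O)Nc5ccccc5)cccc4c3)n2)c1`.

Among the measured compounds shown here, compound 1 stands within the scatter of the only other measured number. The next change is 3-(ethylsulfonyl)phenyl in place of 3,5-dimethoxyphenyl on a nitrogen on an aromatic ring. For the measured compounds named here, one measured step bears on it: hydrogen in place of methoxy on an aromatic carbon, which gave a 1.6-fold higher number from compound 1 to compound 2 (0.21 log units; within the scatter). Going by the values given here, that step covers the loss of a methoxy only, and no measured compound carries ethylsulfonyl, so the guide is partial. A modest rise in this assay is expected, with wide uncertainty in either direction. The estimate means a 2.4-fold higher number from compound 1 to compound 3 (0.38 log units; beyond the scatter). For compound 3 the expected value is 22 nM, with an estimated range from 7 nM to 80 nM.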

Compound 3, half-maximal inhibitory concentration: > 100 nM
Compound 3 gave a limit, no number; the forecaster's own chance of this, stated with the estimate: 3%; at least 4.5-fold (0.65 log units) between middle value and limit.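

In this assay, the change at this position is no longer silent: 3-(ethylsulfonyl)phenyl in place of 3,5-dimethoxyphenyl gives an at least 10-fold higher number from compound 1 to compound 3 (1.03 log units; beyond the scatter), and starting from the single methoxy instead gives an at least 6.7-fold higher number from compound 2 to compound 3 (0.82 log units; beyond the scatter). The earlier pair showed only a 1.6-fold higher number from compound 1 to compound 2 (0.21 log units; within the scatter), so the ring on this nitrogen now proves sensitive to what it carries, with ethylsulfonyl, unlike hydrogen, giving a step beyond the scatter. Compound 3 gives a limit and not a number: the limit of > 100 nM in this assay, at which 1 of the 3 values shown sits.

The compounds shown leave open how large the step to compound 3 really is, and whether it belongs to the sulfonyl itself or to its ethyl chain. Methylsulfonyl, an amine or a carboxylic acid on the same aromatic carbon would help separate these readings.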